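The source may hold more compounds than are shown below. What is called first, only, known or untested is meant among the compounds shown, and "the series" means these compounds.

Measured compounds:
Compound 1 `Cc1cc(Br)cc2c1NC(c1c[nH]nc1-c1cccc3ccccc13)NC2=O` — 3700 nM
Compound 2 `Cc1cccc2c1NC(c1c[nH]nc1-c1ccccc1)NC2=O` — "not determined" (no result reported)

Compound 1 gives 3700 nM in an assay on HEK293 cells for inhibition of transient receptor potential cation channel subfamily M member 2 (Homo sapiens), read by patch clamp, with a stated time of 60 s (on this read-out higher numbers stand for weaker inhibition and lower numbers for stronger inhibition), the only number shown in this set; compound 2 has no reported result there. Compound 3 `Cc1cc(Cl)cc2c1NC(c1c[nH]nc1-c1cccc3ccccc13)NC2=O` differs from compound 1 by chloro in place of bromo on an aromatic carbon, a chloro in place of bromo on an aromatic carbon. With no comparable step between measured compounds shown, a change of one halogen for another is expected to move the read-out little, within the scatter, so the step from compound 1 to compound 3 is estimated at a 1.1-fold higher number from compound 1 to compound 3 (0.03 log units; within the scatter). Compound 3 is therefore expected to give 4000 nM, with a range of 1800 nM to 9000 nM.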

Compound 3, half-maximal inhibitory concentration: 4000 nM
Estimate against measurement, compound 3: no gap at the digits printed; the range from low to high includes it.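

In this assay, within the data shown here, the exchange of bromo for chloro on this aromatic carbon gives a 1.1-fold higher number from compound 1 to compound 3 (0.03 log units; within the scatter) and thus provides the first comparison at this position. At this place on the shared core, the read-out does not separate the two halogens. Nothing measured here explains that result. What the compounds shown leave open is how a group other than a halogen would read at this carbon, such as an amine, a methoxy group or a carboxylic acid. They also leave open whether such a group would move the read-out beyond the scatter.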